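A Fluorine Added to Compound 2, Before Its Measurement

This account rests on a few compounds, and the source may have more. Where it says the series, first, only, none or still open, it means among the compounds named here.

Compound 1, `COc1cc(O)c(C(=O)/C=C/c2ccc(F)cc2)c(OC)c1`: "not active" (no number reported)
Compound 2, `COc1cc(OC)c(C(=O)/C=C/c2ccccc2)c(OC)c1`: 0.7%

Among the compounds with values here, in a functional assay on Huh-7 cells (Homo sapiens), read by fluorescence and BrdU incorporation, with a stated time of 48 h, tested at 25 uM (a higher number here means a weaker effect of the compound at the concentration tested, a lower number a stronger effect), compound 2 gives 0.7%, the only number recorded and a strong effect at the concentration tested. Compound 1 is reported in this assay merely as "not active" (no number reported), without a number. Compound 3, `COc1cc(OC)c(C(=O)/C=C/c2ccc(F)cc2)c(OC)c1`, differs from compound 2 in one place: fluoro in place of hydrogen on an aromatic carbon. Within the data shown here, no measured pair differs in one place, so the size of this step is unknown. A small step in this assay, toward a weaker effect and perhaps within the scatter, is expected: a number 7.3 percentage points higher from compound 2 to compound 3 (within the scatter). For compound 3 the estimate is 8%, within 0% to 40%.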

Compound 3, a percentage reported as activity, at one concentration (the size of the read-out at that concentration, not a potency): 1.1%
Compound 3: the middle estimate sits 6.9 percentage points above what was measured, within the range that was stated.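

In this assay, the change from phenyl to 4-fluorophenyl gives a number 0.4 percentage points higher from compound 2 to compound 3 (within the scatter), so fluoro in place of hydrogen at this place, para to a large group, shows no difference beyond the scatter, and the strong effect seen with compound 2 is also seen with compound 3. The data offer no evidence on the reason for this result. The compounds shown leave open whether an amine, a carboxylic acid or a trifluoromethyl group on this same aromatic carbon would give a similarly strong effect.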